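This account rests on a few compounds, and the source may have more. Where it says the series, first, only, none or still open, it means among the compounds named here.

Measured compounds in a functional assay on MCF7 cells (Homo sapiens) for antiproliferative activity, read by MTT assay, with a stated time of 48 h; on this read-out lower numbers stand for stronger inhibition and higher numbers for weaker inhibition:

compound 1 `O=C(Nc1cccc(/C=C/C(=O)c2nc3ccccc3[nH]2)c1)c1ccccc1`: 11200 nM
compound 2 `O=C(/C=C/c1cccc(NC(=O)c2ccccc2Br)c1)c1nc2ccccc2[nH]1`: 4520 nM
compound 3 `O=C(Nc1cccc(/C=C/C(=O)c2nc3ccccc3[nH]2)c1)c1cc(Cl)cc(Cl)c1`: a limit of the assay, > 100000 nM

Compound 2 holds the lowest of the two real numbers; its nearest neighbour is compound 1, the step being a 2.5-fold lower number from compound 1 to compound 2 (0.39 log units; beyond the scatter). The value of compound 3 is only a limit, (the limit of > 100000 nM in this assay, at which 1 of the 3 values shown sits), so the steps of an at least 8.9-fold higher number from compound 1 to compound 3 (0.95 log units; beyond the scatter) and an at least 22-fold higher number from compound 2 to compound 3 (1.34 log units; beyond the scatter) give only a floor on how much the number rose.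

Compound 4 `O=C(/C=C/c1cccc(NS(=O)(=O)c2ccc(Cl)cc2)c1)c1nc2ccccc2[nH]1` differs from compound 2 in one place: (4-chlorophenyl)sulfonyl in place of (2-bromophenyl)carbonyl on a nitrogen on an aromatic ring. For the measured compounds named here, no measured step exchanges the carbonyl for a sulfonyl, so none bears on it directly. The measured steps show only that removing the bromo costs a 2.5-fold lower number from compound 1 to compound 2 (0.39 log units; beyond the scatter) in reverse and that another change of the aryl ring pushed compound 3 to the limit. Compound 4 loses the bromo and adds a change of a kind not seen, so the number is expected to rise by a 3.3-fold higher number from compound 2 to compound 4 (0.52 log units; beyond the scatter). Compound 4 is therefore estimated at 15000 nM, between 4000 nM and 60000 nM.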

Compound 4, half-maximal inhibitory concentration: 3820 nM
Compound 4: middle estimate off by 3.9-fold (0.59 log units), on the high side; measured number below the stated range.
By their numbers in this assay, from the lowest: compounds 4 and 2 (each within the scatter of the next); then compound 1. At a limit, above all of these: compound 3.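

In this assay, a sulfonyl can take the place of the carbonyl on this nitrogen without a reading beyond the scatter, provided the aryl ring changes with it: a 1.2-fold lower number from compound 2 to compound 4 (0.07 log units; within the scatter). Against the unsubstituted benzoyl the same group does give a step beyond the scatter, a 2.9-fold lower number from compound 1 to compound 4 (0.47 log units; beyond the scatter), so compound 4 joins compound 2 in sitting under compound 1, with a different linking group. Compound 3 stands at a limit rather than a number, so an at least 26-fold lower number from compound 3 to compound 4 (1.41 log units; beyond the scatter) gives only a floor on the fall: the limit of > 100000 nM in this assay, at which 1 of the 4 values shown sits.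

On these data alone, since linking group and ring halogen change together, what each contributes on its own stays open, and a (4-chlorophenyl)carbonyl or a phenylsulfonyl on this nitrogen would separate them. Also open, as far as these compounds go, is how a methylsulfonyl, with no aryl ring, would read here.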